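Removing a Fluoro Group From the Arylhydrazone Ring

The compounds below may be only part of what the source reports. "The series", "measured", "known", "first", "only" and "open" are said of these compounds alone.

Among the compounds with values here, compound 3 `Cn1c(=O)c(=O)n(C2CCCC2)c2nc(N/N=C/c3ccc(F)cc3Cl)ncc21` gives 15200 nM in a functional assay on PC-3 cells (Homo sapiens) for antiproliferative activity, read by MTT assay (on this read-out higher numbers stand for weaker inhibition and lower numbers for stronger inhibition), which places it second highest of the three numbers so far, with compound 2 `COc1cccc(/C=N/Nc2ncc3c(n2)n(C2CCCC2)c(=O)c(=O)n3C)c1` at 20700 nM nearest and compound 1 `Cn1c(=O)c(=O)n(C2CCCC2)c2nc(N/N=C/c3ccc(Cl)cc3)ncc21` at 8420 nM furthest. Compound 4 `Cn1c(=O)c(=O)n(C2CCCC2)c2nc(N/N=C/c3ccccc3Cl)ncc21` differs from compound 3 only on the aromatic ring: hydrogen in place of fluoro on an aromatic carbon. The guides are earlier changes on that same ring: a 1.8-fold higher number from compound 1 to compound 3 (0.26 log units; within the scatter) and a 1.4-fold lower number from compound 2 to compound 3 (0.13 log units; within the scatter), both within the scatter, while a 2.5-fold higher number from compound 1 to compound 2 (0.39 log units; beyond the scatter) was a modest shift beyond it. Removing one fluoro is a smaller change than any of these, so no shift beyond the scatter is expected. Compound 4 is therefore estimated at 14000 nM, with a range from 6500 nM to 30000 nM. This expectation amounts to a 1.1-fold lower number from compound 3 to compound 4 (0.04 log units; within the scatter).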

Compound 4, half-maximal inhibitory concentration: 16300 nM
Compound 4: middle estimate off by 1.2-fold (0.07 log units), on the low side; measured number inside the range.
By their numbers in this assay, from the lowest: compounds 1, 3, 4 and 2 (each within the scatter of the next, the first and the last beyond it).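

With a 1.1-fold higher number from compound 3 to compound 4 (0.03 log units; within the scatter), fluoro and hydrogen on this aromatic carbon, para to a large group, cannot be told apart on this read-out. The 2-chlorophenyl ring also stays close to both earlier rings, with a 1.3-fold lower number from compound 2 to compound 4 (0.10 log units; within the scatter) and a 1.9-fold higher number from compound 1 to compound 4 (0.29 log units; within the scatter) as the two steps, so the fluoro group is not needed to keep this level of activity in compound 3. Nothing measured here explains this tolerance. Going by these compounds, whether an amine, a carboxylic acid or a longer chain on this carbon would shift the number beyond the scatter remains open.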